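This account rests on a few compounds, and the source may have more. Where it says the series, first, only, none or still open, it means among the compounds named here.

In an ADME assay on microsomes from liver (Homo sapiens) for metabolic stability, read by LC-MS, using NADPH, with stated times of 5 min and 30 min, tested at 1 uM (a higher number here means faster removal of the compound, a lower number slower removal), compound 1 `CN(c1ncco1)c1cnc(NCc2c(F)ccc3c2CCO3)n2cnnc12` gives 11 mL.min-1.g-1. Compound 2 `COCCC(=O)Nc1cnc(NCc2c(F)ccc3c2CCO3)n2cnnc12` gives < 3 mL.min-1.g-1, which is a limit of the assay and not a number. Compound 2 therefore stands at the limit of < 3 mL.min-1.g-1 in this assay, at which 1 of the 2 values shown sits, so its true position is not known. Among the compounds with values here, the one measured step is an at least 3.6-fold lower number from compound 1 to compound 2 (0.56 log units; beyond the scatter), where ((2-methoxyethyl)carbonyl)amino takes the place of methyl(1,3-oxazol-2-yl)amino on an aromatic carbon.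

Compound 3 `CN(C)Cc1ccc(C(=O)Nc2cnc(NCc3c(F)ccc4c3CCO4)n3cnnc23)cc1` keeps the shared core and the carbonyl but carries 4-((dimethylamino)methyl)phenyl in place of 2-methoxyethyl on a carbonyl carbon. Within the data shown here, no measured step makes this exact change, so the evidence is thin. The nearest guide is compound 2, whose step an at least 3.6-fold lower number from compound 1 to compound 2 (0.56 log units; beyond the scatter) shows that swapping the group on the shared core can move this assay beyond the scatter. A modest rise is therefore expected, though with low confidence, and it could stay close to the limit. The expected step is an at least 2.0-fold higher number from compound 2 to compound 3 (0.30 log units; that floor lies within the scatter). For compound 3, the estimated intrinsic clearance is 6 mL.min-1.g-1, with an expected range of 3 mL.min-1.g-1 to 14 mL.min-1.g-1.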

Compound 3, intrinsic clearance in microsomes: 13 mL.min-1.g-1
Beside the measured number, compound 3's estimate is 2.2-fold (0.34 log units) below it; the measured number falls inside the stated range.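

The step of an at least 4.3-fold higher number from compound 2 to compound 3 (0.63 log units; beyond the scatter) in this assay comes from placing 4-((dimethylamino)methyl)phenyl in place of 2-methoxyethyl on a carbonyl carbon whose other neighbour is an amide-type nitrogen. The earlier step replaced the whole group on the shared core, whereas this one keeps the carbonyl and the amide-type nitrogen in both compounds, so it shows that changing only the group on the carbonyl carbon can move this read-out beyond the scatter. The change is not a small one, as the group grows from 4 to 10 heavy atoms, gains a six-membered aromatic ring of carbon only, and exchanges an oxygen for a nitrogen, so this single step cannot tell which of these differences goes with the higher number.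

Compound 2 gives < 3 mL.min-1.g-1, which is a limit and not a number, so the full size of the step remains unknown: the limit of < 3 mL.min-1.g-1 in this assay, at which 1 of the 3 values shown sits.

Also open, going by these compounds, is whether the ring or the amine goes with the rise, and a plain phenyl group or a 2-(dimethylamino)ethyl chain on the same carbonyl carbon would help to separate the two.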